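Replacing the Nitro Group: Expected Return of Cytotoxicity

This account rests on a few compounds, and the source may have more. Where it says the series, first, only, none or still open, it means among the compounds named here.

Of the compounds shown here, three sharing one core have been measured in a functional assay on Ehrlich cells (Mus musculus) for cytotoxicity, read by trypan blue exclusion, with a stated time of 2 h, tested at 50 ug/mL; on this read-out higher numbers stand for a stronger effect at the one concentration tested and lower numbers for a weaker effect. Compound 1 `Cc1ccc(C2C(C#N)=C(N)N(c3ccc(S(N)(=O)=O)cc3)C3=C2CCCC3)cc1` gives 80%, compound 2 `N#CC1=C(N)N(c2ccc(S(N)(=O)=O)cc2)C2=C(CCCC2)C1c1ccc(O)cc1` gives 60%, and compound 3 `N#CC1=C(N)N(c2ccc(S(N)(=O)=O)cc2)C2=C(CCCC2)C1c1ccc([N+](=O)[O-])cc1` gives 10%, the lowest of the three. The measured steps show a number 20 percentage points lower from compound 1 to compound 2 (beyond the scatter), a number 70 percentage points lower from compound 1 to compound 3 (beyond the scatter) and a number 50 percentage points lower from compound 2 to compound 3 (beyond the scatter), so both steps that introduced the nitro group fell far beyond the scatter.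

Compound 4 `N#CC1=C(N)N(c2ccc(S(N)(=O)=O)cc2)C2=C(CCCC2)C1c1ccccc1Cl` differs from compound 3 in one place: 2-chlorophenyl in place of 4-nitrophenyl on a saturated ring carbon. The two large steps that brought in the nitro group bear directly on this change, now run in reverse. Removing that group is therefore expected to raise the number well beyond the scatter, a number 50 percentage points higher from compound 3 to compound 4 (beyond the scatter). Compound 4 is expected to give 60%, within a range from 30% to 85%.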

Compound 4, a percentage reported as activity, at one concentration (the size of the read-out at that concentration, not a potency): 5%
For compound 4 the middle estimate is 55 percentage points above the measured one; the measured number lies below the stated range.
By their numbers in this assay, from the lowest: compounds 4 and 3 (each within the scatter of the next); then compound 2; then compound 1.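

In this assay the swap gave a number 5 percentage points lower from compound 3 to compound 4 (within the scatter) and so the effect did not return once the nitro group had gone from this saturated ring carbon. Together with a number 55 percentage points lower from compound 2 to compound 4 (beyond the scatter) and a number 75 percentage points lower from compound 1 to compound 4 (beyond the scatter) this shows that a low number here is not tied to the nitro group alone. Nothing available explains why 2-chlorophenyl behaves this way.

The compounds shown cannot separate the chlorine from its place on the phenyl ring, as 2-chlorophenyl is the only chlorinated group here. As far as these compounds go, how an amine or a carboxylic acid on that ring would read also remains open.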